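The compounds below may be only part of what the source reports. "The series", "measured", "known", "first", "only" and "open" are said of these compounds alone.

The set rests on a shared core, seen in compound 2 `Cc1cccc(NC(=O)CN2CCC(c3nccs3)CC2)c1`. In a functional assay on HEK293 cells for agonist activity at D(4) dopamine receptor (Homo sapiens), read by FLIPR (on this read-out higher numbers stand for an effect only at larger amounts of compound and lower numbers for an effect already at smaller amounts), compound 2 gives 1 nM, the lowest of the three numbers in hand. Compound 1 `Cc1cccc(C(=O)NCN2CCC(c3nccs3)CC2)c1` gives 9.8 nM in this assay, and compound 3 `N#Cc1cccc(C(=O)NCN2CCC(c3cccc[n+]3[O-])CC2)c1` gives 840 nM; both numbers stand clearly apart from that of compound 2, beyond the usual scatter. Compound 4 `Cc1cccc(NC(=O)CN2CCC(c3ccc(O)cn3)CC2)c1` has not yet been measured. It differs from compound 2 by 5-hydroxypyridin-2-yl in place of 1,3-thiazol-2-yl on a saturated ring carbon. Among the compounds with values here, no measured pair isolates that exchange, so the direction of the step is uncertain. The expected step is a 5.0-fold higher number from compound 2 to compound 4 (0.70 log units; beyond the scatter), a modest rise rather than none. Compound 4 is accordingly estimated at 5 nM, within a range from 1 nM to 40 nM.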

Compound 4, half-maximal effective concentration: 3.8 nM
Compound 4: the middle estimate sits 1.3-fold (0.12 log units) above what was measured; low and high end bracket the measured number.
By their numbers in this assay, from the lowest: compound 2; then compound 4; then compound 1; then compound 3.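

In this assay, within the data shown here, the exchange of 1,3-thiazol-2-yl for 5-hydroxypyridin-2-yl on the saturated ring carbon gives a 3.8-fold higher number from compound 2 to compound 4 (0.58 log units; beyond the scatter), the first pair that isolates a change at this position. The step is modest, so this position accepts a six-membered aromatic ring carrying a hydrogen-bond donor at only a small cost in this read-out. Nothing at hand accounts for the rise. The compounds shown do not separate the ring exchange from the hydroxyl itself. On these data alone, an unsubstituted pyridin-2-yl, or a methoxy group or an amine in place of the hydroxyl, remains open.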